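Small amine change, large shift: what will butoxy do?

The source may hold more compounds than are shown below. What is called first, only, known or untested is meant among the compounds shown, and "the series" means these compounds.

Measured in a functional assay on HeLa cells (Homo sapiens) for antiproliferative activity, read by WST assay, with a stated time of 24 h; on this read-out higher numbers stand for weaker inhibition and lower numbers for stronger inhibition:
- compound 1 `C=C[C@]1(C)CC[C@@H](C(=C)CNC(C)(C)C)C[C@H]1C(=C)C`: 25400 nM
- compound 2 `C=C[C@]1(C)CC[C@@H](C(=C)CNC(C)C)C[C@H]1C(=C)C`: 40 nM

Compound 2 has the lower of these two numbers, so it is the stronger inhibitor. Compound 3 `C=C[C@]1(C)CC[C@@H](C(=C)COCCCC)C[C@H]1C(=C)C` differs from it by one change: butoxy in place of isopropylamino on a saturated chain carbon bound to a double-bonded chain carbon. Going by the values given here, only one measured step bears on this, a 640-fold lower number from compound 1 to compound 2 (2.80 log units; beyond the scatter). That large step came from just hydrogen in place of methyl on the amine side chain. Among the compounds with values here, no measured compound carries butoxy, so the direction is a judgement. A large rise from such a low number seems likeliest. The expected step is a 100-fold higher number from compound 2 to compound 3 (2.00 log units; beyond the scatter). For compound 3 the estimated value in this assay is 4000 nM, with an expected range of 250 nM to 40000 nM.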

Compound 3, half-maximal inhibitory concentration: 266000 nM
Compound 3: the middle estimate sits 67-fold (1.82 log units) below what was measured; the whole stated range lies below it.
By their numbers in this assay, from the lowest: compound 2; then compound 1; then compound 3.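

In this assay, butoxy in place of isopropylamino gives a 6700-fold higher number from compound 2 to compound 3 (3.82 log units; beyond the scatter), and butoxy in place of (tert-butyl)amino still gives a 10-fold higher number from compound 1 to compound 3 (1.02 log units; beyond the scatter). At this position, then, butoxy gives a higher number than either amine, even the one that already had a high number, so the earlier amine-to-amine step did not show how far the number could rise. Nothing available explains this rise. The compounds shown leave open whether it follows from the oxygen or from the chain: butylamino, with the same chain on nitrogen, or the shorter ethoxy could help separate the two.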